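Amine substituent exchange on the shared core: compound 4

A few compounds are considered here, and "the series" means these few. Any claim that something is new, unique, unknown or untested is made for them only; others in the source may bear on it.

Measured compounds:
compound 1 `CCC(COC)N(C)c1nc(C)nc2c1nnn2-c1ccc(C(C)C)cc1Br` — 11.2 nM
compound 2 `CCCC(CCC)Nc1nc(C)nc2c1nnn2-c1c(C)cc(C)cc1C` — 4 nM
compound 3 `CCCC(CCC)Nc1nc(C)nc2c1nnn2-c1ccc(Br)cc1Br` — 0.8 nM

All three were run in an in vitro assay on 293-EBNA cells for binding affinity to corticotropin-releasing factor receptor 1 (Homo sapiens); a lower number here means a stronger inhibitor, a higher number a weaker inhibitor. Compound 1 gives the highest of the three numbers; compound 2 stands nearest to it, compound 3 furthest, and both gaps lie beyond the scatter. For the measured compounds named here, the one single-point step in the set is a 5.0-fold lower number from compound 2 to compound 3 (0.70 log units; beyond the scatter), and it concerns the aryl group on the aromatic nitrogen, not the amine side of the core.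

Compound 4 `CCC(Nc1nc(C)nc2c1nnn2-c1ccc(C(C)C)cc1Br)C(=O)OC` differs from compound 1 in that amine side: a group of 8 heavy atoms (5 carbon, 1 nitrogen, 2 oxygen; no ring) in place of a group of 8 heavy atoms (6 carbon, 1 nitrogen, 1 oxygen; no ring), on an aromatic carbon. Going by the values given here, no measured step touches this position, so the step from compound 1 to compound 4 has no direct precedent; compounds 2 and 3 carry a different amine substituent than compound 1 but differ in the aryl group as well, so their values cannot be read as a step for this change alone. With nothing to anchor the direction, the expected step is a 1.3-fold higher number from compound 1 to compound 4 (0.13 log units; within the scatter), that is, no change beyond the scatter, with a wide range. For compound 4 the expected value in this assay is 15 nM, between 4 nM and 60 nM.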

Compound 4, inhibition constant: 19.4 nM
For compound 4 the middle estimate is 1.3-fold (0.11 log units) below the measured one; the measured number falls inside the stated range.
By their numbers in this assay, from the lowest: compound 3; then compound 2; then compounds 1 and 4 (each within the scatter of the next).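

In this assay the amine side of the shared core absorbs this exchange with a 1.7-fold higher number from compound 1 to compound 4 (0.24 log units; within the scatter), so this position accepts a group with 1 hydrogen-bond donor and 1 double bond outside aromatic rings in place of one with 0 hydrogen-bond donors, with no shift beyond the scatter. For the compounds shown here, this is the first reading at this position with the aryl group held constant, which compounds 2 and 3 could not give. Nothing measured here accounts for this outcome.

The entering group differs from the leaving one in several features at once, so the contributions of the hydrogen-bond donor and the carbonyl remain unseparated. From the compounds shown here alone, whether a carboxylic acid or a primary amide in this group would stay within the scatter of compound 1 also remains open.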